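Oxetan-3-yl replacing the acyl group on compound 2

The source may report more compounds than this note shows. Statements on the series, on what has been measured and on what is new or still open speak of the compounds shown alone.

Compound 1 (`COc1cccc2c1c(NS(=O)(=O)c1ccc(Cl)s1)nn2Cc1cccc(CNC(=O)C2CCCO2)c1`) and compound 2 (`COc1cccc2c1c(NS(=O)(=O)c1ccc(Cl)s1)nn2Cc1cccc(CNC(=O)C(C)(C)N)c1`) share a core and differ on a carbonyl carbon. In a physicochemical assay for solubility, read by chemiluminescence, measured as kinetic solubility (on this read-out higher numbers stand for higher solubility and lower numbers for lower solubility), compound 1 gives >= 153 ug/mL, which is a limit. In this assay compound 2 gives >= 180 ug/mL, which is also a limit, so compound 2 has no exact standing. Within the data shown here, the only measured step is a step that the two limits leave unreadable from compound 1 to compound 2, and it offers no size to carry forward.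

Compound 3 (`COc1cccc2c1c(NS(=O)(=O)c1ccc(Cl)s1)nn2Cc1cccc(CNC2COC2)c1`) has oxetan-3-yl in place of (1-amino-1-methylethyl)carbonyl on an amine nitrogen. Among the measured compounds shown here, no measured step covers this change, so the expectation in this assay is for no shift beyond the scatter, with no direction favoured. The expected step is an at least 1.1-fold lower number from compound 2 to compound 3 (0.05 log units; that floor lies within the scatter). For compound 3 the estimated value is 160 ug/mL, with an expected range of 70 ug/mL to 260 ug/mL.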

Compound 3, solubility: 122 ug/mL
Compound 3: the middle estimate sits 1.3-fold (0.12 log units) above what was measured; the range from low to high includes it.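

In this assay, compound 3 carries the only exact number shown at this position, so oxetan-3-yl directly on the amine nitrogen, with no carbonyl there, can now be set against the two amides. The change reads as an at least 1.4-fold lower number from compound 2 to compound 3 (0.16 log units; that floor lies within the scatter), and the other amide gives an at least 1.2-fold lower number from compound 1 to compound 3 (0.09 log units; that floor lies within the scatter). Both floors lie within the scatter, so they fix only a minimum size for each step, and the step between the two amides still cannot be read.

Open, on these data alone, is how far the true numbers of compound 1 and compound 2 lie from compound 3, and so whether removing either acyl group moves the read-out beyond the scatter. Also open, as far as these compounds go, is how a carboxylic acid or a longer chain on this amine nitrogen would read in this assay.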